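Trimming the aryl substituent: tert-butyl to isopropyl

A few compounds are considered here, and "the series" means these few. Any claim that something is new, unique, unknown or untested is made for them only; others in the source may bear on it.

Going by the values given here, compound 2 `CC(C)(C)c1ccc(CCCN2CC=C(CCC(=O)NO)C2=O)cc1` in a functional assay on NUGC-3 cells (Homo sapiens) for inhibition, read by sulforhodamine B assay (on this read-out lower numbers stand for stronger inhibition of growth and higher numbers for weaker inhibition of growth), gives 2200 nM; compound 1 `O=C(CCC1=CCN(CCCc2ccc(Br)cc2)C1=O)NO` in this assay gives 2200 nM, and the single step of no change at the digits printed from compound 1 to compound 2 (within the scatter) shows no change beyond the scatter. Compound 2 thus stands level with compound 1 on the numbers shown. Compound 3 `CC(C)c1ccc(CCCN2CC=C(CCC(=O)NO)C2=O)cc1` differs from compound 2 by hydrogen in place of methyl on a saturated chain carbon bound to an aromatic carbon and two saturated chain carbons. Among the compounds with values here, the only measured step, on the same aromatic position, was flat, and nothing else bears on this change, so no step beyond the scatter is expected in this assay. Compound 3 is estimated at 2200 nM, range 1000 nM to 5000 nM, meaning an expected step of no change at the digits printed from compound 2 to compound 3 (within the scatter).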

Compound 3, concentration for 50% growth inhibition: 2200 nM
Compound 3: the middle estimate sits on the measured number at the digits printed, and the stated range covers the measured number.
By their numbers in this assay, from the lowest: compounds 1, 2 and 3 (each within the scatter of the next).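

In this assay, hydrogen in place of methyl on the saturated chain carbon gives no change at the digits printed from compound 2 to compound 3 (within the scatter) and isopropyl in place of bromo on an aromatic carbon gives no change at the digits printed from compound 1 to compound 3 (within the scatter). Going by these compounds alone, the single flat step thus becomes a level set of three groups: bromo, tert-butyl and isopropyl. No available evidence bears on this flat result.

On these data alone, whether an amine or a carboxylic acid in place of isopropyl would stay level remains open. So does whether plain hydrogen in place of isopropyl would do so.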